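Taking the trifluoromethyl group off compound 1

This account rests on a few compounds, and the source may have more. Where it says the series, first, only, none or still open, it means among the compounds named here.

Of the compounds shown here, two so far have numbers in an ADME assay on microsomes from liver (Mus musculus) for metabolic stability, read by LC-MS, with a stated time of 30 min, tested at 1 uM; a higher number here means that more of the compound is left, a lower number that less of the compound is left. Compound 1 `O=C(NCc1ccc(S(=O)(=O)c2ccccc2C(F)(F)F)cc1)c1cc2cnccc2[nH]1` gives 41%, the higher of the two. Compound 2 `O=C(NCc1ccc(S(=O)(=O)c2cccc(C(F)(F)F)c2)cc1)c1cnc2nccn2c1` gives 27%, and that gap lies beyond the usual scatter. These two compounds do not differ in one place only, so no single structural change has yet been measured.

Compound 3 `O=C(NCc1ccc(S(=O)(=O)c2ccccc2)cc1)c1cc2cnccc2[nH]1` has not been measured. It keeps the rest of compound 1 and carries hydrogen in place of trifluoromethyl on an aromatic carbon, ortho to a large group: hydrogen in place of trifluoromethyl on an aromatic carbon. The same difference, read one bond further out, is 2-(trifluoromethyl)phenyl to phenyl.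

Among the measured compounds shown here, with no measured step to serve as a guide, the only anchor is compound 1 at 41%, and no step beyond the scatter is expected in this assay. The estimated change is small: a number 3 percentage points lower from compound 1 to compound 3 (within the scatter). The data offer little support for this expectation, so the range is kept wide. Compound 3 is expected to give 38%, within an estimated range of 18% to 60%.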

Compound 3, percent of the compound remaining: 54%
For compound 3 the middle estimate is 16 percentage points below the measured one; low and high end bracket the measured number.
By their numbers in this assay, from the lowest: compound 2; then compound 1; then compound 3.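

In this assay, among the compounds shown here, replacing trifluoromethyl with hydrogen on an aromatic carbon, ortho to a large group, gives a number 13 percentage points higher from compound 1 to compound 3 (beyond the scatter) and is the first change in one place to be read. It shows that this place is not indifferent to what it carries: with the shared core and the rest of compound 1 kept, the phenyl form in compound 3 stands beyond the scatter above the 2-(trifluoromethyl)phenyl form in compound 1, although this is a single pair and sets no general pattern. No measurement shown here explains why the number moves with this change.

Going by these compounds, whether a fluorine atom, a methyl group or a methoxy group on this aromatic carbon would give a number closer to that of compound 1 or to that of compound 3 remains open. Also open, on these data alone, is whether the same change would give a similar step on the other side of the molecule's amide, as in compound 2, which carries its trifluoromethyl elsewhere and differs from compound 1 and compound 3 in more than one place.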